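A Nitrile Added to the Ring of Compound 2

The compounds below may be only part of what the source reports. "The series", "measured", "known", "first", "only" and "open" are said of these compounds alone.

Compound 1 `Cc1cnn(C(=O)NCCCCc2ccccc2)c1` and compound 2 `O=C(CCCCCc1ccccc1)n1cccn1` were both tested in an assay on isolated protein for inhibition of Fatty-acid amide hydrolase 1 (Rattus norvegicus), with a stated time of 3 h; on this read-out lower numbers stand for stronger inhibition and higher numbers for weaker inhibition. In this assay compound 1 gives 550 nM. For compound 2 the result is only a limit of the assay, > 5000 nM, and not a number. Compound 2 therefore sits at the limit of > 5000 nM in this assay, at which 1 of the 2 values shown sits, so how weak it truly is cannot be told from the numbers shown. Compound 3 `N#Cc1cnn(C(=O)CCCCCc2ccccc2)c1`, not yet measured, differs from compound 2 in one place: cyano in place of hydrogen on an aromatic carbon. For the measured compounds named here, no measured pair of compounds differs in just one place, so the size of such a step cannot be read from any comparison already in hand. Because compound 2 sits at the limit of > 5000 nM in this assay, at which 1 of the 2 values shown sits, a change that brings compound 3 into the measurable range would show as a gain beyond the scatter, whereas a weakening would leave compound 3 at the same limit. The expectation here is that compound 3 does become measurable, with a step of an at least 25-fold lower number from compound 2 to compound 3 (1.39 log units; beyond the scatter) expected. Compound 3 is estimated to give 200 nM in this assay, with a range from 25 nM to 2000 nM.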

Compound 3, inhibition constant: > 5000 nM
Compound 3: a limit, no number (the forecaster's own chance of this, stated with the estimate: 15%); middle value at least 25-fold (1.39 log units) away from the limit.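

Compound 2 and compound 3 both stay at a limit of this assay, so no step from one to the other can be read for cyano in place of hydrogen: the limit of > 5000 nM in this assay, at which 2 of the 3 values shown sit.

On these data alone, what stays open is how weak compound 2 and compound 3 truly are, and whether the cyano changes their inhibition at all.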